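A few compounds are considered here, and "the series" means these few. Any claim that something is new, unique, unknown or untested is made for them only; others in the source may bear on it.

Measured compounds and their values:
compound 1, `Cc1cc(C)cc(Cc2ccc3c(NCCCNCc4ccco4)ccnc3c2)c1`, 9.47;
compound 2, `COc1ccc(Oc2ccc3c(NCCCNCc4ccco4)ccnc3c2)cc1`, 9.28;
compound 3, `CC(C)(C)c1ccc(-c2ccc3c(NCCCNCc4ccco4)ccnc3c2)cc1`, 9.47.

All three share the same core and side chain and differ only in the group on one aromatic carbon. In a physicochemical assay for acid dissociation, compound 3 stands level with compound 1 at the digits printed, and the two together give the highest of the three numbers; compound 2 lies furthest from compound 3, with a number 0.19 log units higher from compound 2 to compound 3 (within the scatter) separating them.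

Compound 4, `Clc1ccc(Oc2ccc3c(NCCCNCc4ccco4)ccnc3c2)cc1`, is not yet measured. It differs from compound 3 by 4-chlorophenoxy in place of 4-(tert-butyl)phenyl on an aromatic carbon. The steps already seen bear on this change directly: a number 0.19 log units higher from compound 2 to compound 3 (within the scatter) exchanged an aryloxy group for an aryl group, and a number 0.19 log units lower from compound 1 to compound 2 (within the scatter) introduced an aryloxy group in place of a benzyl group. Neither step left the scatter, so an aryloxy group entering in place of an aryl group is expected to move this assay little, if at all.

Compound 4 is therefore expected to give 9.3, in a range from 9 to 9.6, the expected step being a number 0.17 log units lower from compound 3 to compound 4 (within the scatter).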

Compound 4, acid dissociation constant: 9.28
For compound 4 the middle estimate is 0.02 log units above the measured one, within the range that was stated.
By their numbers in this assay, from the lowest: compounds 2, 4, 1 and 3 (each within the scatter of the next).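

In this assay, within the data shown here, chloro in place of methoxy gives no change at the digits printed from compound 2 to compound 4 (within the scatter) and is the first step here that keeps the phenoxy group and alters only the substituent on its ring, which the earlier compounds, exchanging whole groups, could not show. Measured against the other two groups, 4-chlorophenoxy gives a number 0.19 log units lower from compound 3 to compound 4 (within the scatter) and a number 0.19 log units lower from compound 1 to compound 4 (within the scatter) in the same assay, so a second aryloxy group now sits within the scatter of both the aryl and the benzyl group, and no listed compound goes against this. On this aromatic carbon, then, all four groups lie within the scatter of one another, although 4-chlorophenoxy and 4-(tert-butyl)phenyl differ in their heavy atoms and hydrogen-bond acceptors, and nothing measured here gives a reason for this.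

The compounds shown leave open whether this carbon stays as quiet with a group of another kind on it, such as an amine or a carboxylic acid, as all four groups here carry one six-membered aromatic ring of carbon only. They also leave open whether the same holds once the shared side chain gives way to a longer chain.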